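The compounds below may be only part of what the source reports. "The series", "measured", "known", "first", "only" and "open" are said of these compounds alone.

Three compounds have been measured in a functional assay on SW-620 cells (Homo sapiens) for cytotoxicity, read by MTT assay, with stated times of 4 h and 72 h, tested at 5 uM; a lower number here means a stronger inhibitor, a higher number a weaker inhibitor:
compound 1 `COc1ccc(CSc2nc3nc(C)cc(Nc4ccc(C(=O)/C=C/c5ccc6ccccc6c5)cc4)n3n2)cc1` gives 250 nM;
compound 2 `Cc1cc(Nc2ccc(C(=O)/C=C/c3ccc4ccccc4c3)cc2)n2nc(SCc3ccc(F)cc3)nc2n1` gives 320 nM;
compound 3 `Cc1ccc(CSc2nc3nc(C)cc(Nc4ccc(C(=O)/C=C/c5ccc6ccccc6c5)cc4)n3n2)cc1` gives 880 nM.

Compound 3 has the highest number of the three: the step of a 3.5-fold higher number from compound 1 to compound 3 (0.55 log units; beyond the scatter) and the step of a 2.8-fold higher number from compound 2 to compound 3 (0.44 log units; beyond the scatter) both lie beyond the scatter, while a 1.3-fold higher number from compound 1 to compound 2 (0.11 log units; within the scatter) stays within it. All three differ only in the group on the saturated chain carbon bound to a sulfur, and compound 4 `Cc1cc(Nc2ccc(C(=O)/C=C/c3ccc4ccccc4c3)cc2)n2nc(SCc3cccc([N+](=O)[O-])c3)nc2n1` alters that same part once more: 3-nitrophenyl in place of 4-methylphenyl on a saturated chain carbon bound to a sulfur. The two steps that lead into compound 3 bear on this change: each time methyl replaced methoxy or fluoro, the number rose modestly, so swapping methyl out again may be expected to bring it down somewhat. Going by the values given here, the nitro group has no precedent among the measured compounds, and it enters on a different carbon of that ring, so the expectation is loose and the range wide. In this assay compound 4 is expected to give 400 nM, between 150 nM and 1200 nM. The expected step is a 2.2-fold lower number from compound 3 to compound 4 (0.34 log units; beyond the scatter).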

Compound 4, half-maximal inhibitory concentration: 790 nM
The estimate for compound 4 lay 2.0-fold (0.30 log units) below the measured number; low and high end bracket the measured number.
By their numbers in this assay, from the lowest: compounds 1 and 2 (each within the scatter of the next); then compounds 4 and 3 (each within the scatter of the next).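

In this assay the step from the 4-methylphenyl to the 3-nitrophenyl group (a 1.1-fold lower number from compound 3 to compound 4 (0.05 log units; within the scatter)) shows that this position accepts a larger group with a nitro substituent, with no change beyond the scatter. Swapping out the methyl does not by itself bring the number down, since compound 4 stays apart from the 4-fluorophenyl and 4-methoxyphenyl compounds (a 2.5-fold higher number from compound 2 to compound 4 (0.39 log units; beyond the scatter); a 3.2-fold higher number from compound 1 to compound 4 (0.50 log units; beyond the scatter)). No measurement is available that would explain these differences.

Compound 4 changes both the substituent and its place on the ring, so the compounds shown cannot separate the contribution of the nitro group from that of its location. Also open, on these data alone, is how an amine or a carboxylic acid on that ring, or a longer chain linking it to the sulfur, would fare.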